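The source may hold more compounds than are shown below. What is called first, only, known or untested is meant among the compounds shown, and "the series" means these compounds.

Series notes. Compound 1 `Nc1scc(-c2cccc(C(F)(F)F)c2)c1C(=O)c1ccccc1` is the reference bearing hydrogen at the ring carbon of interest; in an assay on CHO-K1 cells for displacement of a labelled ligand from adenosine receptor A1 (Homo sapiens), tested at 10 uM (on this read-out lower numbers stand for less inhibition and higher numbers for more inhibition at the one concentration tested (going by the name of the read-out)), compound 1 gives 61.1%. Compound 2 `CC(=O)c1cccc(-c2sc(N)c(C(=O)c3ccccc3)c2-c2cccc(C(F)(F)F)c2)c1` carries a 3-acetylphenyl there, and in this assay compound 2 gives 33.1%, a step of a number 28 percentage points lower from compound 1 to compound 2 (beyond the scatter). Compound 3 `COc1ccc(-c2sc(N)c(C(=O)c3ccccc3)c2-c2cccc(C(F)(F)F)c2)cc1` carries a 4-methoxyphenyl at the same aromatic carbon; in this assay compound 3 gives 65.2%. This is the highest of the three numbers, but the step of a number 4.1 percentage points higher from compound 1 to compound 3 (within the scatter) lies within the scatter, whereas the step of a number 32.1 percentage points higher from compound 2 to compound 3 (beyond the scatter) lies beyond it; compound 3 is thus not separated from compound 1.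

Compound 4 `Nc1sc(Cl)c(-c2cccc(C(F)(F)F)c2)c1C(=O)c1ccccc1` differs from compound 3 by chloro in place of 4-methoxyphenyl on an aromatic carbon. Among the measured compounds shown here, no measured step introduces chloro at this carbon. For the measured compounds named here, the closest comparison is hydrogen against 4-methoxyphenyl, a number 4.1 percentage points higher from compound 1 to compound 3 (within the scatter), which stayed within the scatter; the only step beyond it, a number 32.1 percentage points higher from compound 2 to compound 3 (beyond the scatter), concerns 3-acetylphenyl. Chloro in place of 4-methoxyphenyl is therefore expected to change little, with the expected step of a number 7.2 percentage points lower from compound 3 to compound 4 (within the scatter) within the scatter and slightly downward. For compound 4 in this assay the estimate is 58%, between 40% and 75%.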

Compound 4, a percentage reported as inhibition, at one concentration (the size of the read-out at that concentration, not a potency): 87.1%
The estimate for compound 4 lay 29.1 percentage points below the measured number; measured number outside the range, above it.
By their numbers in this assay, from the lowest: compound 2; then compounds 1 and 3 (each within the scatter of the next); then compound 4.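

At the ring carbon next to the ring sulfur, chloro separates from the hydrogen reference in this assay, with a number 26 percentage points higher from compound 1 to compound 4 (beyond the scatter), which 4-methoxyphenyl did not do; a change at this carbon can therefore raise the number as well as lower it. Chloro also stands clear of both larger groups, with a number 21.9 percentage points higher from compound 3 to compound 4 (beyond the scatter) and a number 54 percentage points higher from compound 2 to compound 4 (beyond the scatter), so compound 4 is the highest of the four, its steps to all the others being beyond the scatter. Nothing available bears on the reason for this result.

Open, going by these compounds, is whether the higher number belongs to chloro itself or would also come with bromo, methyl or an amine on this carbon. Also open, on these data alone, is where an unsubstituted phenyl would stand relative to 4-methoxyphenyl and 3-acetylphenyl here.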